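Swapping the ring on the amide of compound 3

A few compounds are considered here, and "the series" means these few. Any claim that something is new, unique, unknown or untested is made for them only; others in the source may bear on it.

Compound 3 `CCCCNc1nc(N)nc2c1CN(C(=O)c1csc(C)n1)CC2` carries the highest number of the three measured compounds. In an assay on HEK293 cells for agonist activity at Toll-like receptor 8 (Homo sapiens), read by a luciferase reporter, with a stated time of 6 h (on this read-out lower numbers stand for an effect already at smaller amounts and higher numbers for an effect only at larger amounts of compound), compound 3 gives 1.8 uM, while compound 1 `CCCCNc1nc(N)nc2c1CN(C)CC2` gives 0.03 uM and compound 2 `CCCCNc1nc(N)nc2c1CN(Cc1ccco1)CC2` gives 0.08 uM. The steps of a 60-fold higher number from compound 1 to compound 3 (1.78 log units; beyond the scatter) and a 23-fold higher number from compound 2 to compound 3 (1.35 log units; beyond the scatter) both end at compound 3, whereas a 2.7-fold higher number from compound 1 to compound 2 (0.43 log units; beyond the scatter) is only modest. Compound 4 `CCCCNc1nc(N)nc2c1CN(C(=O)c1csnn1)CC2` keeps the carbonyl on the ring nitrogen and differs only in the ring attached to it: 1,2,3-thiadiazol-4-yl in place of 2-methyl-1,3-thiazol-4-yl on a carbonyl carbon. Within the data shown here, no measured step exchanges one ring for another on a carbonyl carbon; every step so far replaces the whole group on the ring nitrogen. Compound 4 is therefore expected to sit close to compound 3, with a step of a 1.1-fold higher number from compound 3 to compound 4 (0.05 log units; within the scatter) that stays within the scatter. The estimate for compound 4 is 2 uM, in the range 0.7 uM to 6 uM.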

Compound 4, minimum effective concentration: 0.1 uM
Compound 4: the middle estimate sits 20-fold (1.30 log units) above what was measured; the whole stated range lies above it.
By their numbers in this assay, from the lowest: compound 1; then compounds 2 and 4 (each within the scatter of the next); then compound 3.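

On the carbonyl carbon the ring matters a great deal: 1,2,3-thiadiazol-4-yl in place of 2-methyl-1,3-thiazol-4-yl gives an 18-fold lower number from compound 3 to compound 4 (1.26 log units; beyond the scatter) and so recovers most of what compound 3 had lost. A carbonyl on the ring nitrogen therefore need not cost much, since replacing (furan-2-yl)methyl gives only a 1.3-fold higher number from compound 2 to compound 4 (0.10 log units; within the scatter) and replacing methyl gives a modest 3.3-fold higher number from compound 1 to compound 4 (0.52 log units; beyond the scatter) here. No measurement available explains why the two rings differ. On these data alone, the two rings differ in both ring atoms and the methyl, so the share of each stays open. A plain phenyl or an unmethylated 1,3-thiazol-4-yl on the carbonyl carbon would help separate them.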